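The compounds below may be only part of what the source reports. "The series", "measured", "known", "first", "only" and "open" are said of these compounds alone.

Three esters share one core. Compound 1 `CCCCC/C=C/CCCCCCCCCC1(C(=O)OC)CO1` gives 10 mg/kg in a functional assay on the whole organism with Rattus norvegicus as the target, in the glucose tolerance test (on this read-out lower numbers stand for an effect already at smaller amounts and higher numbers for an effect only at larger amounts of compound), compound 2 `COC(=O)C1(CCCCCCCCCCc2ccccc2)CO1` gives 10 mg/kg, and compound 3 `CCCCCCCCCCCCC1(C(=O)OC)CO1` gives 5 mg/kg, the lowest of the three numbers shown, although a 2.0-fold lower number from compound 1 to compound 3 (0.30 log units; within the scatter) and a 2.0-fold lower number from compound 2 to compound 3 (0.30 log units; within the scatter) both lie within the scatter. Compound 4 `CCCCCCCCCCC1(C(=O)OC)CO1` differs from compound 3 by hydrogen in place of ethyl on a saturated chain carbon, ten or more bonds along the chain from a saturated ring carbon. The step that bears most directly on this change is the one at the same place on the chain, which gave a 2.0-fold lower number from compound 2 to compound 3 (0.30 log units; within the scatter); the change at the chain end gave a 2.0-fold lower number from compound 1 to compound 3 (0.30 log units; within the scatter). With neither chain change moving the read-out beyond the scatter, no step beyond the scatter is expected in this assay in either direction: no change at the digits printed from compound 3 to compound 4 (within the scatter). Compound 4 is therefore estimated at 5 mg/kg, within 2.5 mg/kg to 10 mg/kg.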

Compound 4, minimum effective dose: 10 mg/kg
Compound 4: the middle estimate sits 2.0-fold (0.30 log units) below what was measured, within the range that was stated.
By their numbers in this assay, from the lowest: compounds 3, 1, 2 and 4 (each within the scatter of the next).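

Hydrogen in place of ethyl at this position gives a 2.0-fold higher number from compound 3 to compound 4 (0.30 log units; within the scatter) in this assay, so removing ethyl here, like replacing phenyl with ethyl before it, stays inside the scatter. Hydrogen in place of phenyl gives no change at the digits printed from compound 2 to compound 4 (within the scatter), and methyl in place of hept-1-en-1-yl gives no change at the digits printed from compound 1 to compound 4 (within the scatter), so none of these chain changes can be told apart on this read-out. No evidence on the reason for this is at hand. From the compounds shown here alone, whether an amine or a carboxylic acid on this chain carbon would move the read-out beyond the scatter stays open.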